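The source may report more compounds than this note shows. Statements on the series, on what has been measured and on what is new or still open speak of the compounds shown alone.

Measured so far:
compound 1 `O=C(CN1CCN(C(=O)c2ccc(F)cc2)CC1)N1CCN(CCCc2c[nH]c3ccccc23)CC1`: 141000 nM
compound 2 `O=C(CN1CCN(C(=O)c2cccc(Cl)c2)CC1)N1CCN(CCCc2c[nH]c3ccccc23)CC1`: 99100 nM
compound 3 `COc1ccc2[nH]cc(CCCN3CCN(C(=O)CN4CCN(C(=O)c5ccc(F)cc5)CC4)CC3)c2c1`: > 200000 nM

In an ADME assay on HEK293 cells (Homo sapiens) for cytotoxicity, read by MTT assay, with a stated time of 72 h (on this read-out higher numbers stand for weaker inhibition and lower numbers for stronger inhibition), compound 1 gives 141000 nM and compound 2 gives 99100 nM. The change between them is 3-chlorophenyl in place of 4-fluorophenyl on a carbonyl carbon, and the step is a 1.4-fold lower number from compound 1 to compound 2 (0.15 log units; within the scatter). For compound 3 the value is a limit of this assay rather than a number, (the limit of > 200000 nM in this assay, at which 1 of the 3 values shown sits). Compound 3 differs from compound 1 in its core by methoxy in place of hydrogen on an aromatic carbon, giving an at least 1.4-fold higher number from compound 1 to compound 3 (0.15 log units; that floor lies within the scatter).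

Compound 4 `COc1ccc2[nH]cc(CCCN3CCN(C(=O)CN4CCN(C(=O)c5cccc(Cl)c5)CC4)CC3)c2c1` is not yet measured in this assay. From compound 3 it differs by 3-chlorophenyl in place of 4-fluorophenyl on a carbonyl carbon; the place is word for word the same as in the change from compound 1 to compound 2, so this is the same change. The expected step is a number no higher from compound 3 to compound 4 (the limit leaves the size open), resting on the earlier step of a 1.4-fold lower number from compound 1 to compound 2 (0.15 log units; within the scatter), which stayed within the scatter. Compound 4 is thus estimated at 200000 nM, between 100000 nM and 450000 nM, and may well again come back only as a limit.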

Compound 4, half-maximal inhibitory concentration: 143000 nM
Beside the measured number, compound 4's estimate is 1.4-fold (0.15 log units) above it; low and high end bracket the measured number.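

Putting 3-chlorophenyl in place of 4-fluorophenyl on a carbonyl carbon gives an at least 1.3-fold lower number from compound 3 to compound 4 (0.14 log units; that floor lies within the scatter) in this assay, and whether this matches the step on the other core stays open: the same change on two cores in this assay, a 1.4-fold lower number (0.15 log units; within the scatter) from compound 1 to compound 2 and an at least 1.3-fold lower number (0.14 log units; that floor lies within the scatter) from compound 3 to compound 4; the limit leaves it open whether they differ

Methoxy in place of hydrogen on an aromatic carbon gives a 1.4-fold higher number from compound 2 to compound 4 (0.16 log units; within the scatter), with the comparison again left open: the same change on two cores in this assay, an at least 1.4-fold higher number (0.15 log units; that floor lies within the scatter) from compound 1 to compound 3 and a 1.4-fold higher number (0.16 log units; within the scatter) from compound 2 to compound 4; the limit leaves it open whether they differ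

Compound 3 stands at a limit of the assay, > 200000 nM, so these pairs do not show that either change keeps the same size from one core to the other.

Still open, from the compounds shown here alone, is the true size of both steps that involve compound 3. Also open, going by these compounds, is whether a carboxylic acid or an amine in place of the 3-chlorophenyl would move the number in this assay beyond the scatter.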